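The source may hold more compounds than are shown below. What is called first, only, known or untested is meant among the compounds shown, and "the series" means these compounds.

Measured in a functional assay on the whole organism for inhibition, with Rattus norvegicus as the target; a lower number here means that less compound is needed, a higher number that more compound is needed for the effect:
Compound 1 `CC(C)c1ccc(OC(C)(Cc2ccccc2)C(=O)O)cc1`: > 10 mg/kg
Compound 2 `CC(C)c1ccc(OC(C)(Cc2cccc(C(F)(F)F)c2)C(=O)O)cc1`: 5 mg/kg
Compound 3 `CC(C)c1ccc(OC(C)(Cc2cccc(Cl)c2)C(=O)O)cc1`: 5 mg/kg

Compound 1 stands at > 10 mg/kg, which is a limit and not a number. Compound 3 stands at 5 mg/kg, level with compound 2. Compound 4 `Cc1cccc(CC(C)(Oc2ccc(C(C)C)cc2)C(=O)O)c1` carries methyl in place of chloro on an aromatic carbon, (methyl in place of chloro on an aromatic carbon). Going by the values given here, no measured step involves methyl. The nearest evidence is chloro in place of hydrogen, with an at least 2.0-fold lower number from compound 1 to compound 3 (0.30 log units; that floor lies within the scatter), and trifluoromethyl in place of hydrogen, with an at least 2.0-fold lower number from compound 1 to compound 2 (0.30 log units; that floor lies within the scatter). Exchanging the two groups gave no change at the digits printed from compound 2 to compound 3 (within the scatter). On that basis, no step beyond the scatter is expected in this assay, and the expected step is a 1.2-fold higher number from compound 3 to compound 4 (0.08 log units; within the scatter). For compound 4 the estimated value is 6 mg/kg, with an expected range of 3 mg/kg to 12 mg/kg.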

Compound 4, dose for half-maximal effect: < 1 mg/kg
Compound 4: only a limit was reported (the forecaster's own chance of this, stated with the estimate: 20%); middle value at least 6.0-fold (0.77 log units) away from the limit.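

Compound 4 is reported in this assay only as a limit, so its steps are floors: the limit of < 1 mg/kg in this assay, at which 1 of the 4 values shown sits. At this place on the aromatic ring, chloro and trifluoromethyl could not be told apart, yet methyl in place of chloro gives an at least 5.0-fold lower number from compound 3 to compound 4 (0.69 log units; beyond the scatter), and methyl in place of trifluoromethyl gives an at least 5.0-fold lower number from compound 2 to compound 4 (0.69 log units; beyond the scatter). Methyl in place of hydrogen gives an at least 10-fold lower number from compound 1 to compound 4 (1.00 log units; beyond the scatter), so this position now shows steps beyond the scatter, which the earlier compounds did not. Going by these compounds, how far compound 4 lies past its limit remains open. So does whether an ethyl or methoxy group at this place would match methyl.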